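Swapping 4-phenylphenyl for 2-phenylethynyl on compound 3

The compounds below may be only part of what the source reports. "The series", "measured", "known", "first", "only" and "open" are said of these compounds alone.

In a functional assay on NIH3T3 cells (Mus musculus) (on this read-out higher numbers stand for an effect only at larger amounts of compound and lower numbers for an effect already at smaller amounts), compound 1 `Cn1cncc1C(OCc1ccc(C#N)cc1C#Cc1ccc(C#N)cc1)c1ccc(C#N)cc1` gives 11.6 nM as a measured number. Compound 2 `CCCCCCC#Cc1cc(C#N)ccc1COC(c1ccc(C#N)cc1)c1cncn1C` gives > 0.1 nM and that is a limit of the assay, not a number. Compound 3 `Cn1cncc1C(OCc1ccc(C#N)cc1-c1ccc(-c2ccccc2)cc1)c1ccc(C#N)cc1` gives < 0.1 nM and that too is only a limit.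

Compound 4 `Cn1cncc1C(OCc1ccc(C#N)cc1C#Cc1ccccc1)c1ccc(C#N)cc1` changes one group of compound 3 (2-phenylethynyl in place of 4-phenylphenyl on an aromatic carbon), with 2-phenylethynyl in place of 4-phenylphenyl on an aromatic carbon. The most useful guide is compound 1, which carries 2-(4-cyanophenyl)ethynyl at that place. Its measured step of an at least 110-fold lower number from compound 1 to compound 3 (2.06 log units; beyond the scatter) puts compound 3 far under compound 1 and comes from the opposite swap, toward 4-phenylphenyl. The steps a step that the limit leaves unreadable from compound 1 to compound 2 and a number no higher from compound 2 to compound 3 (the limit leaves the size open) give no readable size and add little.

A large rise in the number is therefore expected (an at least 50-fold higher number from compound 3 to compound 4 (1.69 log units; beyond the scatter)) on this single comparison. For compound 4 the estimated value is 5 nM with an expected range from 0.5 nM to 40 nM in this assay's read-out.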

Compound 4, half-maximal effective concentration: 0.1 nM
The estimate for compound 4 lay 50-fold (1.70 log units) above the measured number; the measured number lies below the stated range.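

In this assay, hydrogen in place of cyano on an aromatic carbon gives a 120-fold lower number from compound 1 to compound 4 (2.06 log units; beyond the scatter). The earlier readable step replaced the whole 2-(4-cyanophenyl)ethynyl group, so it could not separate the cyano group from the triple bond; this step keeps the triple bond, which shows that a large fall in the number does not require losing it. The other two steps, a number no lower from compound 3 to compound 4 (the limit leaves the size open) and a number no higher from compound 2 to compound 4 (the limit leaves the size open), cannot be read. Their size stays unknown, because each of them starts from a limit rather than a number, such as this one for compound 3: the limit of < 0.1 nM in this assay, at which 1 of the 4 values shown sits.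

From the compounds shown here alone, whether 2-phenylethynyl and 4-phenylphenyl truly differ in this assay therefore stays open. Going by these compounds, it is also open what an amine or a carboxylic acid would do in place of that cyano group.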